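Iodo in place of butyl on the aryl sulfonamide

The source may hold more compounds than are shown below. What is called first, only, known or untested is meant among the compounds shown, and "the series" means these compounds.

In a functional assay on MCF7 cells (Homo sapiens) for antiproliferative activity, read by sulforhodamine B assay, with a stated time of 48 h (on this read-out higher numbers stand for weaker inhibition and lower numbers for stronger inhibition), compound 1 `Cc1cccc(NS(=O)(=O)c2ccc(N3CCNC3=O)cc2)c1` gives 190 nM, compound 2 `O=C1NCCN1c1ccc(S(=O)(=O)Nc2ccc(F)cc2)cc1` gives 690 nM and compound 3 `CCCCc1ccc(NS(=O)(=O)c2ccc(N3CCNC3=O)cc2)cc1` gives 770 nM. Compound 3 is thus level with compound 2 and clearly weaker than compound 1. Compound 4 `O=C1NCCN1c1ccc(S(=O)(=O)Nc2ccc(I)cc2)cc1` has iodo in place of butyl on an aromatic carbon, para to a large group (iodo in place of butyl on an aromatic carbon). For the measured compounds named here, two measured steps bear on this. Swapping 3-methylphenyl for 4-fluorophenyl gave a 3.6-fold higher number from compound 1 to compound 2 (0.56 log units; beyond the scatter), beyond the scatter, but that change is less like this one. Closer is butyl in place of fluoro, which gave a 1.1-fold higher number from compound 2 to compound 3 (0.05 log units; within the scatter), within the scatter. No step beyond the scatter is therefore expected in this assay. The expected step is a 1.2-fold lower number from compound 3 to compound 4 (0.07 log units; within the scatter). The estimate for compound 4 is 650 nM, with an expected range of 250 nM to 1700 nM.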

Compound 4, half-maximal inhibitory concentration: 600 nM
The estimate for compound 4 lay 1.1-fold (0.03 log units) above the measured number; low and high end bracket the measured number.
By their numbers in this assay, from the lowest: compound 1; then compounds 4, 2 and 3 (each within the scatter of the next).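

In this assay, iodo, a single heavy atom, replaces the four-carbon butyl with a 1.3-fold lower number from compound 3 to compound 4 (0.11 log units; within the scatter) and replaces fluoro with a 1.2-fold lower number from compound 2 to compound 4 (0.06 log units; within the scatter), so these three groups on an aromatic carbon para to a large group read alike. The step beyond the scatter comes with 4-iodophenyl in place of 3-methylphenyl, a 3.2-fold higher number from compound 1 to compound 4 (0.50 log units; beyond the scatter). No measurement here explains this pattern.

An amine or a carboxylic acid on this carbon could still behave differently. The compounds shown also cannot separate the methyl group of compound 1 from its place on the ring.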